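The source may report more compounds than this note shows. Statements on the series, on what has been measured and on what is new or still open speak of the compounds shown alone.

Four related compounds are compared here in an ADME assay on Vero cells (Chlorocebus sabaeus) for cytotoxicity, read by resazurin assay, with a stated time of 72 h; a lower number here means a stronger inhibitor, a higher number a weaker inhibitor. Compound 1 `O=C(CCN1CCN(c2ccc(F)cc2)CC1)c1ccc(Br)cc1` gives 99500 nM in this assay. Compound 2 `O=C(CCN1CCN(c2ccc(Cl)cc2)CC1)c1ccc(Br)cc1` differs from compound 1 by chloro in place of fluoro on an aromatic carbon, and in this assay compound 2 gives 52100 nM, so that the step runs a 1.9-fold lower number from compound 1 to compound 2 (0.28 log units; within the scatter). Compound 3 `O=C(CCN1CCN(c2ccc(F)cc2)CC1)c1ccc(F)c(F)c1` differs from compound 1 by 3,4-difluorophenyl in place of 4-bromophenyl on a carbonyl carbon; in this assay compound 3 gives 385000 nM, and the step is a 3.9-fold higher number from compound 1 to compound 3 (0.59 log units; beyond the scatter). Among the three measured compounds, compound 3 has the highest number, and its steps to both others are beyond the scatter.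

Compound 4 `O=C(CCN1CCN(c2ccc(F)cc2)CC1)c1ccc(F)c(Cl)c1` has not yet been measured. It differs from compound 3 by chloro in place of fluoro on an aromatic carbon. Going by the values given here, this is the same kind of change as the one from compound 1 to compound 2, but the place is not identical: in the earlier pair the exchanged group stands para to a large group, whereas in compound 3 and compound 4 it stands ortho to a fluoro group and meta to a large group. Among the compounds with values here, the only guide to its size is the earlier step, a 1.9-fold lower number from compound 1 to compound 2 (0.28 log units; within the scatter), which stayed within the scatter. On that basis the step from compound 3 to compound 4 is expected to be small as well, around a 1.8-fold lower number from compound 3 to compound 4 (0.24 log units; within the scatter). For compound 4 in this assay an estimate of roughly 220000 nM is expected, likely between 100000 nM and 500000 nM.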

Compound 4, half-maximal inhibitory concentration: 185000 nM
For compound 4 the middle estimate is 1.2-fold (0.08 log units) above the measured one; measured number inside the range.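

In this assay, chloro in place of fluoro on an aromatic carbon moves the number the same way and by a similar amount on both cores: the same change on two cores in this assay, a 1.9-fold lower number (0.28 log units; within the scatter) from compound 1 to compound 2 and a 2.1-fold lower number (0.32 log units; beyond the scatter) from compound 3 to compound 4, 1.1-fold (0.04 log units) apart, within the scatter of two such steps. In these two pairs, then, the change carries over from the core of compound 1 to the core of compound 3, even though it stands at a different place; the new step, a 2.1-fold lower number from compound 3 to compound 4 (0.32 log units; beyond the scatter), lies just beyond the scatter while the earlier one lies just within it, and that split marks no real difference between them. Going by these compounds alone, this rests on only two pairs and two small steps, so it does not show that the change would behave alike on other cores, and it gives no reason for the agreement.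

Exchanging the whole group on the carbonyl gives a step of a 1.9-fold higher number from compound 1 to compound 4 (0.27 log units; within the scatter), which leaves those two groups unseparated in this assay. The compounds shown leave open whether a bromo or methyl group in place of that chloro would follow the same course, and whether the change would still carry over with a longer chain between the carbonyl and the rest of the molecule.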